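The compounds below may be only part of what the source reports. "The series", "measured", "known", "first", "only" and "open" are said of these compounds alone.

- Compound 1 `CCCc1ccc(NC2=CC(=O)c3nc4n(c3C2=O)[C@H]2OC[C@@H](O)[C@H]2OC4)cc1`: > 4000 nM
- Compound 2 `O=C1C(Nc2ccccc2F)=CC(=O)c2c1nc1n2[C@H]2OC[C@@H](O)[C@H]2OC1`: 2660 nM
- Compound 3 `CCc1ccc(NC2=CC(=O)c3c(nc4n3[C@H]3OC[C@@H](O)[C@H]3OC4)C2=O)cc1`: > 4000 nM

In a functional assay on ECa-109 cells for inhibition, with ECa-109 cell line (Homo sapiens) as the target, read by sulforhodamine B assay (on this read-out higher numbers stand for weaker inhibition and lower numbers for stronger inhibition), compound 1 gives > 4000 nM, a limit of the assay and not a number. It stands at the limit of > 4000 nM in this assay, at which 2 of the 3 values shown sit. Compound 4 `O=C1C=C(NC2CCCCC2)C(=O)c2c1nc1n2[C@H]2OC[C@@H](O)[C@H]2OC1` has not yet been measured and differs from compound 1 as follows: cyclohexyl in place of 4-propylphenyl on an amine nitrogen.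

One measured step also changes the group on an amine nitrogen: an at least 1.5-fold higher number from compound 2 to compound 3 (0.17 log units; that floor lies within the scatter). Going by these compounds, it ends at a limit, so its true size is unknown. Within the data shown here, compound 2, at 2660 nM, gives the one actual number. I therefore expect no step beyond the scatter in this assay, and no direction can be assigned. The estimated step is an at least 1.1-fold lower number from compound 1 to compound 4 (0.05 log units; that floor lies within the scatter). For compound 4 the expected value is 3500 nM, with an estimated range of 1500 nM to 8000 nM.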

Compound 4, half-maximal inhibitory concentration: > 16000 nM
Compound 4 was reported as a limit; the forecaster's own chance of this, stated with the estimate: 50%; at least 4.5-fold (0.66 log units) between middle value and limit.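

Compound 1 and compound 4 are both reported only as limits of the assay, and the step between them cannot be read. The compounds shown leave open how cyclohexyl and 4-propylphenyl on the amine nitrogen truly compare.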